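The compounds below may be only part of what the source reports. "The series", "measured", "known", "first", "only" and "open" are said of these compounds alone.

The measured compounds: compound 1 `CCNc1nc(NCc2ccc(C(=O)Nc3ccc(F)cc3)cc2)c2ccccc2n1` with 1900 nM, compound 2 `C=CCNc1nc(NCc2ccc(C(=O)Nc3ccc(F)cc3)cc2)c2cc(C)ccc2n1` with 13000 nM, and compound 3 `CC1CN(c2nc(NCc3ccc(C(=O)Nc4ccc(F)cc4)cc3)c3ccccc3n2)CCN1` with 2800 nM, all in a functional assay on HCT-116 cells (Homo sapiens) for inhibition, read by luminescence and resazurin assay, with a stated time of 3 days; on this read-out lower numbers stand for stronger inhibition and higher numbers for weaker inhibition.

Compound 3 stands second highest of the three numbers in this assay; compound 1 is its nearest neighbour, within the scatter, and compound 2 lies furthest, beyond the scatter. Compound 4 `C=CCNc1nc(NCc2ccc(C(=O)Nc3ccc(F)cc3)cc2)c2ccccc2n1` arises by allylamino in place of 3-methylpiperazin-1-yl on an aromatic carbon. Within the data shown here, the one measured step with a bearing is a 1.5-fold higher number from compound 1 to compound 3 (0.17 log units; within the scatter), which stayed within the scatter, so swapping the 3-methylpiperazin-1-yl group for a small amine gave no clear shift. Compound 2, which also carries allylamino but differs in a second place as well, gives a higher number than compound 1. A modest rise is therefore expected: a 1.3-fold higher number from compound 3 to compound 4 (0.10 log units; within the scatter). Compound 4 is estimated at 3500 nM, within a range from 1500 nM to 9000 nM.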

Compound 4, half-maximal inhibitory concentration: 14000 nM
For compound 4 the middle estimate is 4.0-fold (0.60 log units) below the measured one; the measured number lies above the stated range.
By their numbers in this assay, from the lowest: compounds 1 and 3 (each within the scatter of the next); then compounds 2 and 4 (each within the scatter of the next).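

In this assay the group on the aromatic carbon between two ring nitrogen atoms clearly matters: allylamino in place of 3-methylpiperazin-1-yl (a 5.0-fold higher number from compound 3 to compound 4 (0.70 log units; beyond the scatter)) and vinyl in place of methyl on the ethylamino chain (a 7.4-fold higher number from compound 1 to compound 4 (0.87 log units; beyond the scatter)) both raise the number, so not every small amine matches ethylamino here. Hydrogen in place of methyl on an aromatic carbon (a 1.1-fold higher number from compound 2 to compound 4 (0.03 log units; within the scatter)) makes no clear difference. Nothing available explains the jump between ethylamino and allylamino. Still open, from the compounds shown here alone, is how a saturated propylamino chain or an unsubstituted piperazine would read at this position.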